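The compounds below may be only part of what the source reports. "The series", "measured", "known", "first", "only" and "open" are said of these compounds alone.

Measured compounds:
- compound 1, `COc1ccc(-c2cc(/C=C/C(=O)c3ccc(N)cc3)[nH]n2)cc1`: 6450 nM
- compound 2, `COc1cc(-c2cc(/C=C/C(=O)c3ccc(N)cc3)[nH]n2)cc(OC)c1OC`: 10500 nM
- compound 3, `COc1ccc(C(=O)/C=C/c2cc(-c3cc(OC)c(OC)c(OC)c3)n[nH]2)cc1OC`: 3410 nM

In a functional assay on IGROV-1 cells (Homo sapiens) for inhibition, read by sulforhodamine B assay, with a stated time of 48 h (a higher number here means a weaker inhibitor of growth, a lower number a stronger inhibitor of growth), compound 2 gives 10500 nM, the highest of the three numbers; compound 1 gives 6450 nM, within the scatter of compound 2, and compound 3 gives 3410 nM. For the measured compounds named here, the only measured step, a 3.1-fold lower number from compound 2 to compound 3 (0.49 log units; beyond the scatter), concerns the aryl group on the carbonyl carbon, not the ring changed here.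

Compound 4, `COc1ccc(-c2cc(/C=C/C(=O)c3ccc(N)cc3)[nH]n2)cc1OC`, differs from compound 2 by hydrogen in place of methoxy on an aromatic carbon. Going by the values given here, no measured step touches this position directly. Compounds 1 and 2, which carry fewer or more methoxy groups on this ring, sit within the scatter of each other, so removing one methoxy group is not expected to move this assay beyond the scatter.

Compound 4 is therefore expected to give about 8000 nM, with a range from 3500 nM to 18000 nM. This estimate implies a step of a 1.3-fold lower number from compound 2 to compound 4 (0.12 log units; within the scatter), expected to stay within the scatter.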

Compound 4, concentration for total growth inhibition: 19000 nM
Compound 4: the middle estimate sits 2.4-fold (0.38 log units) below what was measured; the measured number lies above the stated range.
By their numbers in this assay, from the lowest: compounds 3, 1, 2 and 4 (each within the scatter of the next, the first and the last beyond it).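

Taking away this methoxy group gives a 1.8-fold higher number from compound 2 to compound 4 (0.26 log units; within the scatter) in this assay, so on its own this change cannot be told from the usual scatter. Adding a methoxy group to the same ring from the other side gives a 2.9-fold higher number from compound 1 to compound 4 (0.47 log units; beyond the scatter) as a modest step, the only step on this ring that clears the scatter, so one methoxy change on this ring need not count the same in each compound. Nothing measured here accounts for this difference between the two steps.

From the compounds shown here alone, it remains open how a different group at this position, such as a hydroxy group, a fluorine atom or an amine, would read in this assay. Going by these compounds, it is also open whether these steps would hold with 3,4-dimethoxyphenyl in place of 4-aminophenyl on the carbonyl carbon.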